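A sulfur-bearing chain in place of sec-butyl

The compounds below may be only part of what the source reports. "The series", "measured", "known", "first", "only" and "open" are said of these compounds alone.

Compound 2, `CCC(C)[C@@H]1N[C@H](C(=O)NCc2ccccc2)COC1=O`, holds the higher of the two numbers recorded in a functional assay on HEK293 cells with Voltage-dependent T-type calcium channel subunit alpha-1G (Homo sapiens) as the target, read by patch clamp (a lower number here means a stronger inhibitor, a higher number a weaker inhibitor), where compound 2 gives 1220 nM; compound 1, `CC(C)[C@@H]1N[C@H](C(=O)NCc2ccccc2)COC1=O`, gives 990 nM in this assay, and the step of a 1.2-fold higher number from compound 1 to compound 2 (0.09 log units; within the scatter) lies within the scatter. Compound 3, `CSCC[C@@H]1N[C@H](C(=O)NCc2ccccc2)COC1=O`, carries 2-(methylsulfanyl)ethyl in place of sec-butyl on a saturated ring carbon. Among the measured compounds shown here, only that single alkyl step bears on this change, and it was small, so no movement beyond the scatter is expected in this assay, in either direction. Compound 3 is therefore expected to give 1300 nM, between 550 nM and 3200 nM. For compound 3 this means an expected step of a 1.1-fold higher number from compound 2 to compound 3 (0.03 log units; within the scatter) in this assay.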

Compound 3, half-maximal inhibitory concentration: 1860 nM
Compound 3: the middle estimate sits 1.4-fold (0.16 log units) below what was measured; the measured number falls inside the stated range.
By their numbers in this assay, from the lowest: compounds 1, 2 and 3 (each within the scatter of the next).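

In this assay the saturated ring carbon next to the ring nitrogen also accepts 2-(methylsulfanyl)ethyl, which brings a sulfur atom and a hydrogen-bond acceptor into the chain, and neither step leaves the scatter (a 1.5-fold higher number from compound 2 to compound 3 (0.18 log units; within the scatter); a 1.9-fold higher number from compound 1 to compound 3 (0.27 log units; within the scatter)). The three chains therefore cannot be told apart at this position. Nothing available explains this result. As far as these compounds go, whether an amine, a carboxylic acid or a longer chain here would move the number beyond the scatter stays open.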